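The source may hold more compounds than are shown below. What is called first, only, known or untested is meant among the compounds shown, and "the series" means these compounds.

In a functional assay on MGC-803 cells (Homo sapiens) for inhibition, read by MTT assay, with a stated time of 48 h (a lower number here means a stronger inhibitor, a higher number a weaker inhibitor), compound 1 `CCN1CCN(C(=S)SCCCOc2ccc3c(=O)c(-c4ccc(OC)cc4)coc3c2)CC1` gives 54000 nM and compound 2 `COc1ccc(-c2coc3cc(OCCCSC(=S)N4CCN(Cc5ccccc5)CC4)ccc3c2=O)cc1` gives 43800 nM, so the two stand within the scatter of each other. Compound 3 `COc1ccc(-c2coc3cc(OCCCSC(=S)N4CCN(C(C)=O)CC4)ccc3c2=O)cc1` differs from compound 2 by acetyl in place of benzyl on an amine nitrogen in a ring, with acetyl in place of benzyl on an amine nitrogen in a ring. Among the measured compounds shown here, the only measured step bearing on this, a 1.2-fold lower number from compound 1 to compound 2 (0.09 log units; within the scatter), put phenyl in place of methyl on a saturated chain carbon bound to that nitrogen. For the measured compounds named here, no measured compound carries acetyl, so only a change within the scatter is expected, namely a 1.1-fold higher number from compound 2 to compound 3 (0.06 log units; within the scatter). Compound 3 is estimated at 50000 nM, with an expected range of 22000 nM to 100000 nM.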

Compound 3, half-maximal inhibitory concentration: 39400 nM
The estimate for compound 3 lay 1.3-fold (0.10 log units) above the measured number; the measured number falls inside the stated range.
By their numbers in this assay, from the lowest: compounds 3, 2 and 1 (each within the scatter of the next).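

In this assay, compound 3 shows that a substituent on this amine nitrogen in a ring need not be joined through a plain saturated carbon chain: acetyl, with its hydrogen-bond acceptor and no ring, gives a 1.1-fold lower number from compound 2 to compound 3 (0.05 log units; within the scatter) and a 1.4-fold lower number from compound 1 to compound 3 (0.14 log units; within the scatter). Ethyl, benzyl and acetyl at this position therefore all give numbers within the scatter of one another. Nothing available explains this lack of separation.

As far as these compounds go, whether an unsubstituted amine, a carboxylic acid or a longer chain on this nitrogen would move the number beyond the scatter remains open. So does whether any change elsewhere in these compounds would do so.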